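A few compounds are considered here, and "the series" means these few. Any claim that something is new, unique, unknown or untested is made for them only; others in the source may bear on it.

Values so far in a functional assay on SK-MEL-147 cells (Homo sapiens) for cytotoxicity, read by MTT assay, with a stated time of 24 h; a lower number here means that less compound is needed, a higher number that more compound is needed for the effect
Compound 1 `CCCCC#Cc1cc(C(=O)OCC)nc2ccc(OC)cc12` gives 7200 nM
Compound 2 `CCOC(=O)c1cc([Se]c2ccc(F)cc2)c2cc(OC)ccc2n1` gives only a limit, > 150000 nM
Compound 3 `CCOC(=O)c1cc([Se]c2ccccc2)c2cc(Cl)ccc2n1` gives 47100 nM

Of the two exact numbers, compound 3 (47100 nM) has the higher one, and compound 1 (7200 nM) the lower. Compound 4 `CCOC(=O)c1cc([Se]c2ccccc2)c2ccccc2n1` makes a single change to compound 3 (hydrogen in place of chloro on an aromatic carbon), with hydrogen in place of chloro on an aromatic carbon.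

Within the data shown here, only one measured step exists, an at least 20-fold higher number from compound 1 to compound 2 (1.31 log units; beyond the scatter), and it is large. It exchanges a different group, however, so it shows that numbers in this assay can move far in these compounds but does not test the loss of chloro. Among the measured compounds shown here, no measured pair isolates this swap. With so little evidence, the estimate stays near compound 3 (47100 nM) and leans only slightly upward. The expected change is a 1.5-fold higher number from compound 3 to compound 4 (0.17 log units; within the scatter), which is a tentative expectation. For compound 4 the estimated value is 70000 nM, expected to lie between 25000 nM and 150000 nM.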

Compound 4, half-maximal effective concentration: 86300 nM
The estimate for compound 4 lay 1.2-fold (0.09 log units) below the measured number; measured number inside the range.
By their numbers in this assay, from the lowest: compound 1; then compounds 3 and 4 (each within the scatter of the next). At a limit, above all of these: compound 2.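

In this assay hydrogen in place of chloro on an aromatic carbon gives a 1.8-fold higher number from compound 3 to compound 4 (0.26 log units; within the scatter). Among these compounds, this is the first measured step at this position of the shared core, and it shows that, with the rest of the molecule held constant, losing the chloro leaves the number within the usual scatter, unlike the large step seen earlier at a different place. Nothing shown gives a cause for this result.

From the compounds shown here alone, whether a larger or differently built group at this place, such as an amine or a carboxylic acid, would move the number beyond the scatter remains open. Going by these compounds, it is also open whether the same swap of chloro for hydrogen would give a similar result with the chain of compound 1 in place of the selenium-linked ring.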